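This account rests on a few compounds, and the source may have more. Where it says the series, first, only, none or still open, it means among the compounds named here.

Measured in a functional assay on A549 cells (Homo sapiens), read by sulforhodamine B assay, with a stated time of 5 days; on this read-out higher numbers stand for weaker inhibition of growth and lower numbers for stronger inhibition of growth:
- compound 1 `OC[C@H]1O[C@@H](n2cc(F)c3c(-c4ccccc4)ncnc32)[C@H](O)[C@@H]1O`: > 10000 nM, a limit of the assay
- compound 2 `OC[C@H]1O[C@@H](n2cc(F)c3c(-c4ccsc4)ncnc32)[C@H](O)[C@@H]1O`: 380 nM

Going by the values given here, compound 2 holds the only actual number so far. The other entry in the series is the limit of > 10000 nM in this assay, at which 1 of the 2 values shown sits.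

Next is compound 3 `OC[C@H]1O[C@@H](n2cc(F)c3c(-c4cc[nH]c4)ncnc32)[C@H](O)[C@@H]1O`, with 1H-pyrrol-3-yl in place of thiophen-3-yl on an aromatic carbon.

Among the compounds with values here, one measured step bears on this place: an at least 26-fold lower number from compound 1 to compound 2 (1.42 log units; beyond the scatter). Swapping the group here can therefore move the number strongly. Compound 3 keeps a five-membered aromatic ring with 1 hetero atom, as compound 2 does. Within the data shown here, no measured step exchanges one such ring for another, so in this assay no change beyond the scatter is expected, though the uncertainty is wider towards higher numbers. The expected step is a 1.2-fold higher number from compound 2 to compound 3 (0.07 log units; within the scatter). For compound 3 the estimate is 450 nM, with an expected range of 90 nM to 3000 nM.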

Compound 3, concentration for 50% growth inhibition: 130 nM
Compound 3: middle estimate off by 3.5-fold (0.54 log units), on the high side; low and high end bracket the measured number.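

In this assay, the two five-membered aromatic rings with 1 hetero atom are not interchangeable on this aromatic carbon: 1H-pyrrol-3-yl in place of thiophen-3-yl gives a 2.9-fold lower number from compound 2 to compound 3 (0.47 log units; beyond the scatter), with 1 hydrogen-bond donor entering and 1 hydrogen-bond acceptor leaving. Against phenyl, 1H-pyrrol-3-yl gives an at least 76-fold lower number from compound 1 to compound 3 (1.88 log units; beyond the scatter), so both five-membered rings shown lie clearly apart from the six-membered phenyl ring. The value of compound 1 is a limit of the assay, so this step fixes only a minimum size: the limit of > 10000 nM in this assay, at which 1 of the 3 values shown sits.

Going by these compounds, whether the hydrogen-bond donor of the ring, or only the change of hetero atom from sulfur to nitrogen, goes with the step stays open. A reading for furan-3-yl or 1-methyl-1H-pyrrol-3-yl at this place would separate the two.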